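The source may report more compounds than this note shows. Statements on the series, on what has been measured and on what is new or still open speak of the compounds shown alone.

Measured so far:
compound 1, `CC(C)(/C=C1\OC(=O)NC1=O)c1ccc(-c2ccc3cccc(F)c3c2)[nH]c1=O` — in a functional assay on CHO cells for antagonist activity at prostaglandin E2 receptor EP3 subtype (Homo sapiens), read by cAMP accumulation, with a stated time of 30 min (a lower number here means a stronger inhibitor, a higher number a weaker inhibitor), compound 1 gives 57 nM
compound 2, `CC(C)C(c1ccc(-c2ccc3cccc(F)c3c2)[nH]c1=O)C1C(=O)NC(=O)N1C` — in this assay compound 2 gives 320 nM

Compound 2 has the higher of the two numbers, and its gap to compound 1 is beyond the scatter. Compound 3, `CC(C)C(CC1C(=O)NC(=O)N1C)c1ccc(-c2ccc3cccc(F)c3c2)[nH]c1=O`, is not yet measured. It differs from compound 2 by one change: (3-methyl-2,5-dioxoimidazolidin-4-yl)methyl in place of 3-methyl-2,5-dioxoimidazolidin-4-yl on a saturated chain carbon bound to an aromatic carbon and a saturated chain carbon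

Among the compounds with values here, no pair of measured compounds differing in one place is available, so the step from compound 2 to compound 3 rests on no direct precedent. A small step is expected, a 1.3-fold lower number from compound 2 to compound 3 (0.11 log units; within the scatter), in no firm direction. Compound 3 is estimated at 250 nM, with a range from 80 nM to 800 nM.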

Compound 3, half-maximal inhibitory concentration: 65 nM
Compound 3: middle estimate off by 3.8-fold (0.59 log units), on the high side, outside the stated range (below it).
By their numbers in this assay, from the lowest: compounds 1 and 3 (each within the scatter of the next); then compound 2.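

In this assay, (3-methyl-2,5-dioxoimidazolidin-4-yl)methyl in place of 3-methyl-2,5-dioxoimidazolidin-4-yl gives a 4.9-fold lower number from compound 2 to compound 3 (0.69 log units; beyond the scatter), the only one-place step shown, and it lies beyond the scatter. This saturated chain carbon therefore responds to a single added carbon before the five-membered ring. Nothing at hand bears on why the number falls. On these data alone, whether a longer chain at this place would lower the number further remains open, as does whether a carboxylic acid could replace the five-membered ring.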